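The compounds below may be only part of what the source reports. "The series", "measured", "known", "first", "only" and "open" are said of these compounds alone.

Measured so far in a functional assay on HUVEC cells (Homo sapiens) for inhibition, with stated times of 2 h and 72 h; on this read-out higher numbers stand for weaker inhibition and lower numbers for stronger inhibition:
compound 1, `COc1cc2nccc(Oc3ccc4c(NC(=O)c5ccc(C(F)(F)F)cc5)nn(C)c4c3)c2cc1OC`: 79 nM
compound 2, `COc1cc2nccc(Oc3ccc4c(NC(=O)Nc5ccc(C)cc5)nn(C)c4c3)c2cc1OC`: 3 nM
compound 3, `COc1cc2nccc(Oc3ccc4c(NC(=O)c5cc(C(F)(F)F)cc(C(F)(F)F)c5)nn(C)c4c3)c2cc1OC`: 58 nM

Among these three numbers compound 1 gives the highest. Compound 3 sits within the scatter of compound 1, so the two are not told apart here. Within the data shown here, compound 2 stands far away, with a 26-fold lower number from compound 1 to compound 2 (1.42 log units; beyond the scatter), the one step that lies beyond the scatter in this set.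

Compound 4, `COc1ccc(C(=O)Nc2nn(C)c3cc(Oc4ccnc5cc(OC)c(OC)cc45)ccc23)cc1`, keeps the shared core and the amide of compound 1 and differs from it only in the para substituent of the phenyl on the carbonyl carbon: methoxy in place of trifluoromethyl on an aromatic carbon.

Among the measured compounds shown here, no measured step bears directly on this change. The step from compound 1 to compound 2 replaces the whole 4-(trifluoromethyl)phenyl with (4-methylphenyl)amino, a different kind of change, and its size cannot be carried over. Compounds 1 and 3 show that a second trifluoromethyl on that phenyl leaves the number within the scatter. With no guide of its own, compound 4 is expected to stay close to compound 1, with a step of a 1.6-fold lower number from compound 1 to compound 4 (0.20 log units; within the scatter) in this assay. Compound 4 is therefore estimated at 50 nM, with a range from 15 nM to 160 nM.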

Compound 4, half-maximal inhibitory concentration: 32 nM
Compound 4: the middle estimate sits 1.6-fold (0.19 log units) above what was measured, and the stated range covers the measured number.
By their numbers in this assay, from the lowest: compound 2; then compounds 4, 3 and 1 (each within the scatter of the next, the first and the last beyond it).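

In this assay, the trifluoromethyl-to-methoxy exchange on an aromatic carbon, para to a large group, gives a 2.5-fold lower number from compound 1 to compound 4 (0.39 log units; beyond the scatter), a modest step. Among these compounds, it shows that this single substituent can move the number beyond the scatter while the amide stays in place, which the earlier compounds could not show, since the one large step among them replaced the whole 4-(trifluoromethyl)phenyl. Even so, an 11-fold higher number from compound 2 to compound 4 (1.03 log units; beyond the scatter) remains a large step, so methoxy at this position does not bring the amide series close to the (4-methylphenyl)amino group of compound 2, and nothing available explains the effect of the methoxy group.

Going by these compounds, it remains open whether a dimethylamino group, a carboxylic acid or a longer chain such as ethoxy at the same position would lower the number further or raise it. On these data alone, it is equally open whether methoxy in place of the methyl of the (4-methylphenyl)amino group in compound 2 would shift the number in the same direction.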